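One Halogen Swap on the Dichloro Compound

A few compounds are considered here, and "the series" means these few. Any claim that something is new, unique, unknown or untested is made for them only; others in the source may bear on it.

Compound 1 `O=S(=O)(/C=C/c1ccccc1)Cc1ccc(Nc2ncnc3ccccc23)cc1`: 58000 nM.
Compound 2 `O=S(=O)(/C=C/c1ccc(Cl)cc1)Cc1ccc(Nc2ncnc3ccccc23)cc1`: > 100000 nM, a limit of the assay and not a number.
Compound 3 `O=S(=O)(/C=C/c1ccc(Cl)cc1Cl)Cc1ccc(Nc2ncnc3ccccc23)cc1`: 100 nM.

All three were tested in a functional assay on ACHN cells (Homo sapiens); on this read-out higher numbers stand for weaker inhibition of growth and lower numbers for stronger inhibition of growth. Compound 3 has the lowest number of the set, and both steps leading to it lie beyond the scatter: a 580-fold lower number from compound 1 to compound 3 (2.76 log units; beyond the scatter) and an at least 1000-fold lower number from compound 2 to compound 3 (3.00 log units; beyond the scatter).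

Compound 4 `O=S(=O)(/C=C/c1ccc(F)cc1Cl)Cc1ccc(Nc2ncnc3ccccc23)cc1` differs from compound 3 in a single substituent: fluoro in place of chloro on an aromatic carbon. Here, fluoro takes the place of chloro on an aromatic carbon, para to a large group. Among the compounds with values here, the chloro that leaves is the one compound 2 also carries, and adding it alone gave an at least 1.7-fold higher number from compound 1 to compound 2 (0.23 log units; that floor lies within the scatter). The other chloro, whose addition gave an at least 1000-fold lower number from compound 2 to compound 3 (3.00 log units; beyond the scatter), remains in compound 4. A moderate rise is therefore expected, far smaller than that drop, although such large jumps within this small set call for a wide range.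

The expected change is a 4.0-fold higher number from compound 3 to compound 4 (0.60 log units; beyond the scatter). Compound 4 is estimated at 400 nM, with an expected range from 50 nM to 10000 nM.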

Compound 4, concentration for 50% growth inhibition: 73000 nM
The estimate for compound 4 lay 180-fold (2.26 log units) below the measured number, and the stated range ends below it.
By their numbers in this assay, from the lowest: compound 3; then compounds 1 and 4 (each within the scatter of the next). At a limit, above all of these: compound 2.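

Fluoro in place of chloro at this place, para to a large group, gives a 730-fold higher number from compound 3 to compound 4 (2.86 log units; beyond the scatter), so the low number of compound 3 depends on this chloro and not only on the other chloro, which compound 4 keeps. With that other chloro kept and fluoro here, the step from plain phenyl to the 2-chloro-4-fluorophenyl group is a 1.3-fold higher number from compound 1 to compound 4 (0.10 log units; within the scatter), so compound 1 and compound 4 cannot be told apart. Compound 2 stands at a limit of the assay and not a number: the limit of > 100000 nM in this assay, at which 1 of the 4 values shown sits. The step that starts from this limit is an at least 1.3-fold lower number from compound 2 to compound 4 (0.13 log units; that floor lies within the scatter), and it gives only a floor.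

Still open, as far as these compounds go, is whether a bromo, a methyl or a methoxy at this place would keep the low number of compound 3. The compounds shown also do not explain why only the 2,4-dichlorophenyl group gives such a low number.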